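A few compounds are considered here, and "the series" means these few. Any claim that something is new, unique, unknown or untested is made for them only; others in the source may bear on it.

Measured in a functional assay on L1210 cells (Mus musculus) for inhibition, with a stated time of 48 h; a lower number here means a stronger inhibitor, a higher number a weaker inhibitor:
Compound 1 `CCNCCCNCCCNCC`: > 100000 nM
Compound 2 `CCNCCCCNCCCN`: > 100000 nM
Compound 3 `CCCNCCCCNCCCN`: > 100000 nM

Each of these entries is a limit of the assay and not a number. Compound 3 gives > 100000 nM, which is such a limit. It therefore stands with the other two compounds, at the limit of > 100000 nM in this assay, at which 3 of the 3 values shown sit.

Compound 4 `CCCNCCCCNCCCCN` differs from compound 3 in one place: aminomethyl in place of amino on a saturated chain carbon, three bonds along the chain from an amine nitrogen. The change is aminomethyl in place of amino on a saturated chain carbon, three bonds along the chain from an amine nitrogen.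

Within the data shown here, only one measured step is available, a step that the two limits leave unreadable from compound 2 to compound 3. It concerns a different change, methyl in place of hydrogen on a saturated chain carbon, and it gives no size to carry over. Among the measured compounds shown here, no compound has yet given a number in this assay, so neither a size nor a direction can be drawn from the data. The expectation is therefore no step beyond the scatter, with compound 4 most likely reported as a limit again.

The expected change is a step that the limit leaves unreadable from compound 3 to compound 4, which is an estimate resting on a limit. For compound 4 the estimated value is 150000 nM, with an expected range from 60000 nM to 400000 nM.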

Compound 4, half-maximal inhibitory concentration: 100000 nM
Estimate against measurement, compound 4: 1.5-fold (0.18 log units) above; the range from low to high includes it.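

In this assay compound 4 gives 100000 nM as the first entry in the series that is a number and not a limit. Compound 3 gives > 100000 nM and this is a limit of the assay. Aminomethyl in place of amino on a saturated chain carbon, three bonds along the chain from an amine nitrogen, therefore reads as a number no higher from compound 3 to compound 4 (the limit leaves the size open) and so this place yields a readable value but no readable size of change, while most of the series still sits at one limit: the limit of > 100000 nM in this assay, at which 3 of the 4 values shown sit.

The compounds shown leave open whether 2-aminoethyl or 3-aminopropyl in place of the aminomethyl would carry the value in this assay clearly away from this limit or leave it where it is. They also leave open whether the amine of that group matters at all, which hydroxymethyl or a plain ethyl group at the same place would test.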